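Taking the ethyl group off compound 1

This account rests on a few compounds, and the source may have more. Where it says the series, first, only, none or still open, it means among the compounds named here.

In a functional assay on PC-3 cells (Homo sapiens) for cytotoxicity, read by MTT assay, with a stated time of 72 h (on this read-out higher numbers stand for weaker inhibition and lower numbers for stronger inhibition), compound 1 (`CCc1ccc(-c2cc(C(=O)Nc3ccc(Oc4ccnc(C(=O)NC)c4)cc3)ncn2)cc1`) gives 29300 nM and compound 2 (`CCc1ccc(-c2cc(C(=O)Nc3ccc(Oc4ccnc(C(=O)NC)c4)c(F)c3)ncn2)cc1`) gives 15600 nM, so the two stand within the scatter of each other. Compound 3 (`CNC(=O)c1cc(Oc2ccc(NC(=O)c3cc(-c4ccccc4)ncn3)cc2)ccn1`) has hydrogen in place of ethyl on an aromatic carbon, 4-ethylphenyl to phenyl (hydrogen in place of ethyl on an aromatic carbon). Within the data shown here, no measured step touches the ethyl group. The only one is a 1.9-fold lower number from compound 1 to compound 2 (0.27 log units; within the scatter) for a different change, fluoro in place of hydrogen, so no step beyond the scatter is expected in this assay. The expected step is a 1.2-fold lower number from compound 1 to compound 3 (0.07 log units; within the scatter) in this estimate. Compound 3 is estimated at 25000 nM ( range 9000 nM to 65000 nM) in this read-out.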

Compound 3, half-maximal inhibitory concentration: 44200 nM
For compound 3 the middle estimate is 1.8-fold (0.25 log units) below the measured one; the measured number falls inside the stated range.
By their numbers in this assay, from the lowest: compounds 2, 1 and 3 (each within the scatter of the next, the first and the last beyond it).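

Among these compounds, the change from 4-ethylphenyl to phenyl gives a 1.5-fold higher number from compound 1 to compound 3 (0.18 log units; within the scatter) in this assay, the first direct reading at this position. With ethyl or hydrogen on this aromatic carbon, the two compounds cannot be told apart, so ethyl is not needed to keep the number in this range. Nothing available explains this result. Open, from the compounds shown here alone, is whether a methoxy group, an amine or a longer chain in this place would move the number beyond the scatter.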